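Swapping One Ring Substituent: From Compound 3 to Compound 4

A few compounds are considered here, and "the series" means these few. Any claim that something is new, unique, unknown or untested is made for them only; others in the source may bear on it.

Of the compounds shown here, three have so far been tested in an assay on isolated protein for inhibition of Apoptosis regulator Bcl-2 (Homo sapiens), read by fluorescence polarization; on this read-out higher numbers stand for weaker inhibition and lower numbers for stronger inhibition. Compound 1, `O=C(Nc1ccc(O)c(C(=O)O)c1)c1ccc(/C=C2\SC(=S)N(c3ccccc3)C2=O)cc1`, gives > 10000 nM, which is a limit and not a measured number. Compound 2, `O=C(Nc1cccc(C(=O)O)c1O)c1ccc(/C=C2\SC(=S)N(c3ccc([N+](=O)[O-])cc3)C2=O)cc1`, likewise reaches only the limit > 10000 nM. Compound 3, `Cc1cccc(N2C(=O)/C(=C/c3ccc(OCc4ccc(C(=O)O)cc4)cc3)SC2=S)c1`, also stops at the limit > 10000 nM. Among the compounds with values here, all three therefore stand in the same place, namely (the limit of > 10000 nM in this assay, at which 3 of the 3 values shown sit), so none of them shows measurable inhibition and no step between measured compounds can be read off.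

Compound 4, `O=C(O)c1ccc(COc2ccc(/C=C3\SC(=S)N(c4ccc(Cl)cc4)C3=O)cc2)cc1`, is the next compound to be measured in this assay. It differs from compound 3 in one place: 4-chlorophenyl in place of 3-methylphenyl on an amide-type nitrogen in a ring. Within the data shown here, because every compound tested so far sits at the limit of > 10000 nM in this assay, at which 3 of the 3 values shown sit, there is no measured step of this kind on which to build an expectation, and a swap of one ring substituent is expected to move the result little, if at all, beyond the scatter. Compound 4 is therefore expected to give 15000 nM in this assay, most likely again reported as a limit, with a range from 4000 nM to 50000 nM. The estimated step is a step that the limit leaves unreadable from compound 3 to compound 4, that is, no change beyond the scatter.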

Compound 4, inhibition constant: > 10000 nM
Compound 4 ended at the assay's limit (the forecaster's own chance of this, stated with the estimate: 75%); the middle value lies beyond the limit too.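

Compound 4 gives > 10000 nM, which is a limit and not a measured number. Compound 3 also stops at a limit, so no step can be read from compound 3 to compound 4. The compounds shown leave open which structural change, if any, would give a measurable inhibition value, as all share one result: the limit of > 10000 nM in this assay, at which 4 of the 4 values shown sit.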